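Working notes: from compound 3 to compound 4

The compounds below may be only part of what the source reports. "The series", "measured", "known", "first", "only" and "open" are said of these compounds alone.

Values in an ADME assay on microsomes from liver (Macaca fascicularis) for metabolic stability, read by LC-MS, with a stated time of 65 min, tested at 1 uM (on this read-out lower numbers stand for a less stable compound and higher numbers for a more stable compound), for the series
compound 1 `Fc1cc2nc(-c3cncnc3)n(C3CC3)c2cc1F` gives 98%
compound 2 `CC(C)c1ncncc1-c1nc2cc(F)c(F)cc2n1C1CC1` gives 80%
compound 3 `Fc1cc2nc(-c3cncnc3NCCC(F)(F)F)n(C3CC3)c2cc1F` gives 55%

In this assay the numbers put compound 3 lowest of the three, with a number 43 percentage points lower from compound 1 to compound 3 (beyond the scatter) and a number 25 percentage points lower from compound 2 to compound 3 (beyond the scatter) as the two steps that reach it. The first of these is large and the second modest.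

The next compound to be measured is compound 4 `Fc1cc2nc(-c3cncnc3C(F)F)n(C3CC3)c2cc1F` which carries difluoromethyl in place of (3,3,3-trifluoropropyl)amino on an aromatic carbon, next to the ring nitrogen (difluoromethyl in place of (3,3,3-trifluoropropyl)amino on an aromatic carbon). Among the compounds with values here, no measured compound carries difluoromethyl, so the evidence is indirect. The closest guide is the modest step with isopropyl, a number 18 percentage points lower from compound 1 to compound 2 (beyond the scatter) which stays smaller than either step that reaches compound 3. Within the data shown here, compound 2 (80%) is the only measured compound in which a group other than the (3,3,3-trifluoropropyl)amino group fills this place.

A rise beyond the scatter, of modest size, is therefore expected in this assay on leaving compound 3. The expected step is a number 27 percentage points higher from compound 3 to compound 4 (beyond the scatter) in this direction. The estimate for compound 4 is 82% (expected range from 65% to 96%).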

Compound 4, percent of the compound remaining: 106%
Compound 4: the middle estimate sits 24 percentage points below what was measured; the whole stated range lies below it.
By their numbers in this assay, from the lowest: compound 3; then compound 2; then compounds 1 and 4 (each within the scatter of the next).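

In this assay this place, on an aromatic carbon of a six-membered aromatic ring with 2 nitrogen, proves able to take a substituent with no change beyond the scatter, as a number 8 percentage points higher from compound 1 to compound 4 (within the scatter) shows, so difluoromethyl stands level with hydrogen here. Compounds 1 to 3 alone could have suggested that any group in this place costs stability, but the cost depends on the group: a number 26 percentage points higher from compound 2 to compound 4 (beyond the scatter) and a number 51 percentage points higher from compound 3 to compound 4 (beyond the scatter) set isopropyl and (3,3,3-trifluoropropyl)amino apart from difluoromethyl at the same carbon of the shared core. The data shown offer no independent measurement that would account for this difference between the groups.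

The compounds shown leave open whether a methyl or a trifluoromethyl in this place would also stay level with hydrogen, and whether a propylamino chain without fluorine would sit as low as the (3,3,3-trifluoropropyl)amino group. On these data alone, it also remains open whether difluoromethyl would keep this standing if an ethyl group replaced the cyclopropyl on the shared core.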